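The compounds below may be only part of what the source reports. "The series", "measured", "known", "first", "only" and "open" are said of these compounds alone.

Working notes on the series. In a functional assay for antagonist activity at transient receptor potential cation channel subfamily V member 1 (Homo sapiens), read by FLIPR and calcium flux (a higher number here means a weaker inhibitor, a lower number a stronger inhibitor), compound 1 `CC(=O)N1CCc2cccc(NC(=O)C3CCN(c4cccc(C(F)(F)F)c4)CC3)c21` gives 5610 nM, compound 2 `O=C(Nc1ccc2c(c1)NC(=O)C(CCO)O2)C1CCN(c2cc(F)c(F)c(F)c2)CC1` gives 5 nM, and compound 3 `O=C1COc2ccc(NC(=O)C3CCN(c4ccccc4Br)CC3)cc2N1` gives 160 nM. Compound 3 therefore stands second highest of the three numbers, beyond the scatter on both sides: compound 2 sits well below it and compound 1 well above it. Compound 4 `O=C1COc2ccc(NC(=O)C3CCN(c4ccccc4C(F)(F)F)CC3)cc2N1` keeps the core of compound 3 and differs only in trifluoromethyl in place of bromo on an aromatic carbon. Within the data shown here, no measured pair in this set shows this exact exchange, so the expectation rests on the size of the group alone. Compound 4 is expected to show a small step, a 1.4-fold higher number from compound 3 to compound 4 (0.14 log units; within the scatter), toward a weaker inhibitor, not clearly beyond the scatter. The estimate for compound 4 in this assay is 220 nM, with a range from 60 nM to 800 nM.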

Compound 4, half-maximal inhibitory concentration: 380 nM
For compound 4 the middle estimate is 1.7-fold (0.24 log units) below the measured one; the range from low to high includes it.
By their numbers in this assay, from the lowest: compound 2; then compound 3; then compound 4; then compound 1.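

In this assay, among these compounds, trifluoromethyl in place of bromo on this aromatic carbon, ortho to a large group, gives a 2.4-fold higher number from compound 3 to compound 4 (0.38 log units; beyond the scatter), the first one-place comparison. The position therefore responds to the group it carries, although the step is modest. Nothing available accounts for this step.

As far as these compounds go, it remains open whether chloro, methyl or methoxy on this carbon would give a number nearer that of compound 3 or that of compound 4. From the compounds shown here alone, it is also open whether the same exchange would give a similar step on another core.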